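Cytotoxicity on liver cells across the quinolinone-benzimidazole series

The source may hold more compounds than are shown below. What is called first, only, known or untested is meant among the compounds shown, and "the series" means these compounds.

Measured compounds:
compound 1 `Cc1ccc2[nH]c(=O)c(-c3nc4cc([N+](=O)[O-])ccc4[nH]3)cc2c1`: > 100000 nM
compound 2 `O=c1[nH]c2ccccc2cc1-c1nc2cc(Br)ccc2[nH]1`: > 100000 nM
compound 3 `COc1ccc2[nH]c(=O)c(-c3nc4cc(C)c(C)cc4[nH]3)cc2c1`: > 100000 nM

All three values come from an ADME assay on L02 cells (Homo sapiens) for cytotoxicity, read by MTT assay, with a stated time of 48 h; a lower number here means a stronger inhibitor, a higher number a weaker inhibitor. The value of compound 1 is a limit, not a number. The value of compound 2 is likewise a limit. The value of compound 3 is also a limit. Compound 1 therefore stands at the assay limit together with the other two, as the evidence shows: the limit of > 100000 nM in this assay, at which 3 of the 3 values shown sit. Among the measured compounds shown here, no step between measured compounds can be sized, since every value shown is a limit.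

Compound 4 `Cc1ccc2[nH]c(=O)c(-c3nc4cc(Cl)ccc4[nH]3)cc2c1` is not yet measured in this assay. It differs from compound 1 in one place: chloro in place of nitro on an aromatic carbon. Given that compound 1, compound 2 and compound 3 all sit at the limit, the expected step from compound 1 to compound 4 is none beyond the scatter, which in this assay would most likely be reported once more as a limit. The estimate for compound 4 in this assay is 150000 nM, with a range from 60000 nM to 400000 nM, which means an expected step that the limit leaves unreadable from compound 1 to compound 4.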

Compound 4, half-maximal inhibitory concentration: > 100000 nM
Compound 4 was reported as a limit; the forecaster's own chance of this, stated with the estimate: 85%; the middle value does not contradict the limit.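

In this assay compound 4 gives > 100000 nM, a limit and not a number. No step from compound 1 to compound 4 can be read, as both sit at the limit: the limit of > 100000 nM in this assay, at which 4 of the 4 values shown sit.

The compounds shown leave open how far any of them lies beyond that limit, and whether any change on the shared core gives a readable value.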